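Replacing the Methoxyphenyl Group on the Amide

The source may report more compounds than this note shows. Statements on the series, on what has been measured and on what is new or still open speak of the compounds shown alone.

Measured so far in a functional assay on A549 cells (Homo sapiens) for inhibition, read by MTT assay, with a stated time of 72 h; on this read-out lower numbers stand for stronger inhibition and higher numbers for weaker inhibition
Compound 1 `CCCCc1ccc(NC(=O)C2CCN(C/C=C/c3ccccc3)CC2)cc1` gives 5910 nM
Compound 2 `CCCCCc1ccc(NC(=O)C2CCN(C/C=C/c3ccccc3)CC2)cc1` gives 3880 nM
Compound 3 `COc1ccc(NC(=O)C2CCN(C/C=C/c3ccccc3)CC2)cc1` gives 83800 nM

Compound 3 stands highest of the three, which means the weakest inhibition here: the data show a 14-fold higher number from compound 1 to compound 3 (1.15 log units; beyond the scatter) and also a 22-fold higher number from compound 2 to compound 3 (1.33 log units; beyond the scatter) in this read-out. The butyl and pentyl compounds cannot be told apart, with a 1.5-fold lower number from compound 1 to compound 2 (0.18 log units; within the scatter) between them.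

Compound 4 `O=C(Nc1ccc(F)c(Br)c1)C1CCN(C/C=C/c2ccccc2)CC1` carries 3-bromo-4-fluorophenyl in place of 4-methoxyphenyl on an amide-type nitrogen, and 3-bromo-4-fluorophenyl in place of 4-methoxyphenyl on an amide-type nitrogen sums up what changes. For the measured compounds named here, no measured compound carries bromine or fluorine, so no step matches this swap directly. Going by the values given here, the only guide is that compound 3, the one methoxy compound, sits well above the others, as a 14-fold higher number from compound 1 to compound 3 (1.15 log units; beyond the scatter) shows, so moving away from methoxy may lower the number, though probably by less than that. The step expected in this assay is a 5.6-fold lower number from compound 3 to compound 4 (0.75 log units; beyond the scatter) and remains uncertain. For compound 4 the estimated value is 15000 nM within an expected range from 4500 nM to 50000 nM in this assay.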

Compound 4, half-maximal inhibitory concentration: 11700 nM
Compound 4: the middle estimate sits 1.3-fold (0.11 log units) above what was measured, and the stated range covers the measured number.
By their numbers in this assay, from the lowest: compounds 2, 1 and 4 (each within the scatter of the next, the first and the last beyond it); then compound 3.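

In this assay, the step of a 7.2-fold lower number from compound 3 to compound 4 (0.86 log units; beyond the scatter) shows that a lower number at this amide nitrogen does not depend on a long alkyl chain. Until now, only the butyl and pentyl compounds stood well below the methoxy compound, whereas 3-bromo-4-fluorophenyl carries no such chain and still gives a clearly lower number than 4-methoxyphenyl. The data shown offer no measured explanation for this step.

Because bromine and fluorine enter together while methoxy leaves, the compounds shown leave open how much of the step belongs to each halogen and how much to the loss of methoxy. Also open, going by these compounds, is how a plain phenyl, a 4-fluorophenyl, a 3-bromophenyl or a phenyl bearing a carboxylic acid would read at this position.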